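Fluoro in Place of Cyano on an Aromatic Carbon

This account rests on a few compounds, and the source may have more. Where it says the series, first, only, none or still open, it means among the compounds named here.

Compound 1 `CC(C)CCn1c(CN2CCN(C(=O)c3ccco3)CC2)nc2ccccc21` gives 42.1%.
Compound 2 `Cc1cccc(Cn2c(CN3CCN(C(=O)c4ccc(C#N)cc4)CC3)nc3ccccc32)c1` gives 20.8%.
Compound 3 `O=C(C1CC1)N1CCN(Cc2nc3ccccc3n2CC2CCCC2)CC1` gives 44.5%.

All three were tested in an assay on isolated protein for inhibition of aldehyde dehydrogenase 1A1 (Homo sapiens), read by spectrophotometry, tested at 10 uM; a higher number here means more inhibition at the concentration tested (going by the name of the read-out), a lower number less inhibition. Compound 2 stands lowest of the three: compound 1 lies above it by a margin beyond the scatter, and compound 3 lies further above still. Compound 4 `Cc1cccc(Cn2c(CN3CCN(C(=O)c4ccc(F)cc4)CC3)nc3ccccc32)c1` has not yet been measured. It differs from compound 2 in one place: fluoro in place of cyano on an aromatic carbon. Among the measured compounds shown here, no pair of measured compounds differs in only one place, so nothing here shows how such a change has moved the numbers before. The change is small in what it removes and adds, and the expected step of a number 5.2 percentage points higher from compound 2 to compound 4 (within the scatter) is a modest rise that may well stay within the scatter. Compound 4 is therefore estimated at 26%, with a range from 8% to 48%.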

Compound 4, a percentage reported as inhibition, at one concentration (the size of the read-out at that concentration, not a potency): 27.1%
For compound 4 the middle estimate is 1.1 percentage points below the measured one; low and high end bracket the measured number.
By their numbers in this assay, from the lowest: compounds 2 and 4 (each within the scatter of the next); then compounds 1 and 3 (each within the scatter of the next).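

In this assay, fluoro in place of cyano on this aromatic carbon, para to a large group, gives a number 6.3 percentage points higher from compound 2 to compound 4 (within the scatter). This first single-place comparison therefore shows that, with the rest of the structure held fixed, 4-cyanophenyl and 4-fluorophenyl cannot be told apart in this read-out. Nothing available explains why the two groups read alike. Going by these compounds, whether an amine, a carboxylic acid or a methoxy group on the same carbon would separate from these two remains open. So does whether the plain phenyl would.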